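Opening the Cyclopropyl Ring to an Alkene Ether

The compounds below may be only part of what the source reports. "The series", "measured", "known", "first", "only" and "open" are said of these compounds alone.

The measured compounds and their values in an assay on cells with melanin-concentrating hormone receptor 1 (Homo sapiens) as the target, read by radioligand binding; on this read-out lower numbers stand for stronger inhibition and higher numbers for weaker inhibition:

Compound 1 `Nc1ccc2cccc(OCCC(F)(F)F)c2n1` gives 722 nM.
Compound 2 `CC1CC1COc1cccc2ccc(N)nc12` gives 1640 nM.
Compound 3 `Nc1ccc2cccc(OCC3CC3)c2n1` gives only a limit, > 2000 nM.

Among the three, compound 3 stands at the weak end: its value is the assay limit rather than a number, and it is the one of three sitting at the limit of > 2000 nM in this assay, at which 1 of the 3 values shown sits. The change from compound 1 to compound 3 was an at least 2.7-fold higher number from compound 1 to compound 3 (0.44 log units; beyond the scatter), and from compound 1 to compound 2 it was a 2.3-fold higher number from compound 1 to compound 2 (0.36 log units; beyond the scatter); the change from compound 2 to compound 3 was an at least 1.2-fold higher number from compound 2 to compound 3 (0.08 log units; that floor lies within the scatter).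

Compound 4 `CC(C)=CCOc1cccc2ccc(N)nc12` differs from compound 3 by 2-methylprop-1-en-1-yl in place of cyclopropyl on a saturated chain carbon bound to an oxygen on an aromatic ring. The measured steps show that each departure from the trifluoroethyl group of compound 1 toward a small hydrocarbon ether weakened binding, with the methyl-bearing ring of compound 2 and the plain ring of compound 3 within the scatter of each other. For compound 4 the branched alkene is expected to land near compound 2, an expected step of an at least 1.2-fold lower number from compound 3 to compound 4 (0.09 log units; that floor lies within the scatter), so compound 4 is estimated at 1600 nM, between 500 nM and 5000 nM.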

Compound 4, half-maximal inhibitory concentration: > 2000 nM
Compound 4 was reported as a limit; the forecaster's own chance of this, stated with the estimate: 35%; at least 1.2-fold (0.09 log units) between middle value and limit.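

In this assay compound 4 gives > 2000 nM, which is a limit and not a number. Opening the ring to the alkene chain did not recover the binding seen with the trifluoroethyl ether, with an at least 2.7-fold higher number from compound 1 to compound 4 (0.44 log units; beyond the scatter), while an at least 1.2-fold higher number from compound 2 to compound 4 (0.08 log units; that floor lies within the scatter) shows no separation from the methyl-bearing ring. The step between compound 3 and compound 4 cannot be read, and the group at the limit now holds an open-chain ether as well as a ring ether: the limit of > 2000 nM in this assay, at which 2 of the 4 values shown sit.

The compounds shown leave open how far compound 3 and compound 4 lie past that limit. They also leave open whether a longer saturated chain, such as butyl, or a chain ending in a nitrile, would come back toward compound 1.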